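A few compounds are considered here, and "the series" means these few. Any claim that something is new, unique, unknown or untested is made for them only; others in the source may bear on it.

Within the data shown here, compound 1 `CS(=O)(=O)c1ccc2c(c1)CCN2c1ncnc2c(C3CCN(c4ncccn4)CC3)coc12` gives 512 nM in a functional assay on cells for agonist activity at Glucose-dependent insulinotropic receptor (Homo sapiens), read by a luciferase reporter, with a stated time of 4 h (on this read-out lower numbers stand for an effect already at smaller amounts and higher numbers for an effect only at larger amounts of compound), the only single number in this small set. Compound 2 `CC(C)(C)OC(=O)N1CCC(c2coc3c(N4CC(C)(C)c5cc(S(C)(=O)=O)ccc54)ncnc23)CC1` is reported as "not active" (no number reported) in this assay. For compound 3 `CC(C)(C)OC(=O)N1CCC(c2c[nH]c3c(Nc4ccc(S(C)(=O)=O)cc4F)ncnc23)CC1` the read-out in this assay is a limit rather than a number, > 1000 nM, which is the limit of > 1000 nM in this assay, at which 1 of the 3 values shown sits. Among the measured compounds shown here, no pair of measured compounds differs in a single place, so no measured step is available to anchor the next change. Compound 4 `COc1cnc(N2CCC(c3coc4c(N5CCc6cc(S(C)(=O)=O)ccc65)ncnc34)CC2)nc1` differs from compound 1 by methoxy in place of hydrogen on an aromatic carbon. The expected step of a 1.2-fold lower number from compound 1 to compound 4 (0.09 log units; within the scatter) in this assay is small, with no movement beyond the usual scatter in either direction. Compound 4 is estimated at 420 nM in this assay, within a range from 150 nM to 1200 nM.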

Compound 4, half-maximal effective concentration: 310 nM
For compound 4 the middle estimate is 1.4-fold (0.13 log units) above the measured one, within the range that was stated.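

In this assay, the series now has its first step in a single place, a 1.7-fold lower number from compound 1 to compound 4 (0.22 log units; within the scatter). The carbon two atoms from the ring nitrogen and para to a large group therefore accepts methoxy in place of hydrogen without movement beyond the usual scatter. Nothing on hand bears on why this step is so small.

Open, from the compounds shown here alone, is whether a larger or charged group at this carbon, such as an amine or a carboxylic acid, would also leave the read-out within the scatter. Going by these compounds, a longer chain on the oxygen, such as ethoxy, is equally open.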